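The source may hold more compounds than are shown below. What is called first, only, known or untested is meant among the compounds shown, and "the series" means these compounds.

Measured so far in an ADME assay on A549 cells (Homo sapiens) for cytotoxicity, read by resazurin assay, with a stated time of 48 h; a higher number here means that more compound is tolerated, a lower number that less compound is tolerated:
compound 1 `CC(=O)Nc1ccc(NC(=O)c2cc(Cl)ccc2O)c(Cl)c1`: "not determined" (no result reported)
compound 2 `O=C(Nc1ccc(NCc2ccc(Br)s2)cc1Cl)c1cc(Cl)ccc1O`: 20700 nM

In this assay, for the measured compounds named here, compound 2 gives 20700 nM and stands as the only number available, while compound 1 has no result reported. Going by the values given here, compound 2 therefore cannot be ranked against anything, and no measured step shows how the series responds to a structural change.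

The next compound, not yet measured, is compound 3 `O=C(Nc1ccc(NCCCO)cc1Cl)c1cc(Cl)ccc1O`. It differs from compound 2 in one place: 2-hydroxyethyl in place of 5-bromothiophen-2-yl on a saturated chain carbon bound to a nitrogen on an aromatic ring. Here 2-hydroxyethyl stands in place of 5-bromothiophen-2-yl on a saturated chain carbon bound to a nitrogen on an aromatic ring. Cut one bond further out, the same difference reads (5-bromothiophen-2-yl)methyl to 3-hydroxypropyl.

With a single value to start from, the expectation rests on that value and the structural change alone, so it is uncertain. A moderate shift towards more compound tolerated is expected, and the estimated change is a 1.9-fold higher number from compound 2 to compound 3 (0.29 log units; within the scatter) in this assay. For compound 3 the estimate is 40000 nM with an expected range from 15000 nM to 100000 nM.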

Compound 3, half-maximal cytotoxic concentration: 106000 nM
Beside the measured number, compound 3's estimate is 2.7-fold (0.42 log units) below it, and the stated range ends below it.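

The exchange gives the series its first measured step at this position: in this assay, 2-hydroxyethyl in place of 5-bromothiophen-2-yl on a saturated chain carbon bound to a nitrogen on an aromatic ring gives a 5.1-fold higher number from compound 2 to compound 3 (0.71 log units; beyond the scatter) and lies beyond the usual scatter. The number read in this assay therefore responds to what is carried at this place, and the step runs towards more compound tolerated. In this one step the five-membered aromatic ring, the sulfur and the bromine all leave while a hydrogen-bond donor enters, and nothing available accounts for the shift.

The compounds shown leave open which of these differences carries the step, as all of them change together between the only two numbers available. Also open, on these data alone, is where the number would lie with an unsubstituted thiophene, a phenyl ring, a longer chain ending in a hydroxyl group, or an amine or a carboxylic acid at the end of the 3-hydroxypropyl chain.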